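The compounds below may be only part of what the source reports. "The series", "measured", "known", "first", "only" and "open" are said of these compounds alone.

Measured so far:
- compound 1 `COc1ccc(Oc2ccc3c(NCCCNCc4cccc(OC)c4O)ccnc3c2)cc1`: 14500 nM
- compound 2 `c1ccc(-c2ccc3c(NCCCNCc4ccco4)ccnc3c2)cc1`: 32000 nM
- compound 3 `COc1cccc(CNCCCNc2ccnc3cc(-c4ccccc4)ccc23)c1O`: 32000 nM

These three compounds were tested in a physicochemical assay for solubility, with a stated time of 18 h, at pH 7.4 (on this read-out higher numbers stand for higher solubility and lower numbers for lower solubility), where compound 2 and compound 3 give the same reading at the digits shown, and compound 1 gives the lowest reading of the three. The difference between compound 3 and compound 2 lies in the group on the chain: furan-2-yl in place of 2-hydroxy-3-methoxyphenyl on a saturated chain carbon bound to an amine nitrogen. Across that change no change at the digits printed from compound 2 to compound 3 (within the scatter), so the two cores behave alike on this read-out. From compound 3 to compound 1 the change is 4-methoxyphenoxy in place of phenyl on an aromatic carbon, and it produced a 2.2-fold lower number from compound 3 to compound 1 (0.34 log units; beyond the scatter).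

Compound 4 `COc1ccc(Oc2ccc3c(NCCCNCc4ccco4)ccnc3c2)cc1` has not yet been measured. Among the measured compounds shown here, it differs from compound 2 by 4-methoxyphenoxy in place of phenyl on an aromatic carbon, the same change, at the same place, as the one from compound 3 to compound 1. Because that change gave a 2.2-fold lower number from compound 3 to compound 1 (0.34 log units; beyond the scatter), a step of about the same size is expected here, namely a 2.1-fold lower number from compound 2 to compound 4 (0.33 log units; beyond the scatter). Compound 4 is therefore estimated to give 15000 nM in this assay, with a range from 7000 nM to 32000 nM.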

Compound 4, solubility: 14500 nM
Beside the measured number, compound 4's estimate is 1.0-fold (0.01 log units) above it; low and high end bracket the measured number.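

In this assay, putting 4-methoxyphenoxy in place of phenyl gave a 2.2-fold lower number from compound 2 to compound 4 (0.34 log units; beyond the scatter) on one core and a 2.2-fold lower number from compound 3 to compound 1 (0.34 log units; beyond the scatter) on the other, which means the change carried over at the same size between these two cores. With 4-methoxyphenoxy present, furan-2-yl in place of 2-hydroxy-3-methoxyphenyl gave no change at the digits printed from compound 1 to compound 4 (within the scatter) and with phenyl present the opposite swap gave no change at the digits printed from compound 2 to compound 3 (within the scatter) as well, which means the two changes appear to act independently of each other in these four compounds. This is one pair of cores in one read-out, which does not show that the change would hold on any other core, and nothing given here explains the drop.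

The compounds shown leave open whether the same step appears with other groups on that aromatic carbon, such as a morpholine or a carboxylic acid. They also leave open whether it survives an amine or a longer chain in place of the furan-2-yl end, or holds in any read-out other than this assay at all.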